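From chloro to hydrogen on an aromatic carbon

A few compounds are considered here, and "the series" means these few. Any claim that something is new, unique, unknown or untested is made for them only; others in the source may bear on it.

Compound 1 `COc1c(Br)cccc1C(=O)Nc1ccccc1` value > 100000 nM
Compound 2 `COc1ccccc1C(=O)Nc1cccc(Cl)c1` value > 100000 nM

In an ADME assay on HEK293 cells (Homo sapiens) for cytotoxicity, read by reporter gene assay and resazurin assay, with a stated time of 48 h (a lower number here means that less compound is tolerated, a higher number that more compound is tolerated), compound 1 gives > 100000 nM as a limit of the assay and not a number. Compound 2 gives > 100000 nM in the same way, again only a limit. Compound 2 therefore has no exact place on the scale (the limit of > 100000 nM in this assay, at which 2 of the 2 values shown sit) and shares this standing with compound 1.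

Compound 3 `COc1ccccc1C(=O)Nc1ccccc1` is compound 2 with a single change: hydrogen in place of chloro on an aromatic carbon meta to a large group. Going by the values given here, no two measured compounds differ in just one place, so no direct guide to the size of this change exists. The expectation in this assay is no step beyond the usual scatter and no clear direction. It rests on compound 2 with its limit of > 100000 nM as the only nearby reference. The expected step of a number no higher from compound 2 to compound 3 (the limit leaves the size open) is therefore small, and another limit is the most likely report. For compound 3 the estimated value is 100000 nM with an expected range (40000 nM to 200000 nM) around it.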

Compound 3, half-maximal cytotoxic concentration: > 100000 nM
Compound 3: a limit, no number (the forecaster's own chance of this, stated with the estimate: 85%); the middle value sits exactly at the limit.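

In this assay compound 3 gives > 100000 nM, which is a limit and not a number. No step can be read among compound 1, compound 2 and compound 3, as all three stand at the same point: the limit of > 100000 nM in this assay, at which 3 of the 3 values shown sit.

The compounds shown leave open whether removing chloro or bromo changes the concentration these cells tolerate, and at what concentration any of the three becomes toxic.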